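The source may report more compounds than this note shows. Statements on the series, on what has been measured and on what is new or still open speak of the compounds shown alone.

Measured so far:
- compound 1, `CC(=O)c1ccc(NC(=O)/C=C/C(=O)N2C/C(=C\c3ccc([N+](=O)[O-])cc3)C(=O)/C(=C/c3ccc([N+](=O)[O-])cc3)C2)cc1`: 360 nM
- compound 2, `Cc1cccc(C)c1NC(=O)/C=C/C(=O)N1C/C(=C\c2ccc([N+](=O)[O-])cc2)C(=O)/C(=C/c2ccc([N+](=O)[O-])cc2)C1`: 230 nM

Both compounds share one core and differ only in the aryl group on the amide-type nitrogen. Compound 2 has the lowest of the two numbers in a functional assay on CCRF-CEM cells (Homo sapiens) for cytotoxicity; a lower number here means a stronger inhibitor, a higher number a weaker inhibitor; its nearest neighbour is compound 1, and the step of a 1.6-fold lower number from compound 1 to compound 2 (0.19 log units; within the scatter) lies within the scatter, so the two cannot be told apart. Compound 3, `O=C(/C=C/C(=O)N1C/C(=C\c2ccc([N+](=O)[O-])cc2)C(=O)/C(=C/c2ccc([N+](=O)[O-])cc2)C1)Nc1ccccc1`, keeps the same core and carries phenyl in place of 2,6-dimethylphenyl on an amide-type nitrogen. For the measured compounds named here, only one measured step bears on a change at this position, and it is the small one from compound 1 to compound 2; nothing measured tells whether a plain phenyl behaves differently. Compound 3 is therefore expected to give a number close to that of compound 2, the step of a 1.3-fold higher number from compound 2 to compound 3 (0.12 log units; within the scatter) being estimated as no change beyond the scatter. The estimate for compound 3 is 300 nM, within a range of 120 nM to 750 nM.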

Compound 3, half-maximal inhibitory concentration: 370 nM
For compound 3 the middle estimate is 1.2-fold (0.09 log units) below the measured one; measured number inside the range.
By their numbers in this assay, from the lowest: compounds 2, 1 and 3 (each within the scatter of the next).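

In this assay, the plain phenyl of compound 3 can be set against both earlier aryl groups: replacing 2,6-dimethylphenyl gives a 1.6-fold higher number from compound 2 to compound 3 (0.21 log units; within the scatter), and replacing the acetyl group with hydrogen gives a 1.0-fold higher number from compound 1 to compound 3 (0.01 log units; within the scatter). Both steps lie within the scatter, so phenyl, 2,6-dimethylphenyl and 4-acetylphenyl on this amide-type nitrogen cannot be told apart, and neither the two methyl groups nor the acetyl group is shown to matter here. No independent measurement is available to explain this result.

Going by these compounds, it remains open whether an amine or a carboxylic acid on this aromatic ring would shift the number beyond the scatter. On these data alone, it is also open whether a cyclohexyl group or a longer alkyl chain could take the place of the aromatic ring on this nitrogen.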